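Urea series: chloro for trifluoromethyl on the aryl urea

The compounds below may be only part of what the source reports. "The series", "measured", "known", "first", "only" and "open" are said of these compounds alone.

Measured so far:
compound 1 `O=C(Nc1cccc(-n2cc(-c3ccncc3)c(-c3cc(O)cc(Cl)c3)n2)c1)Nc1ccc(Cl)c(Cl)c1`, 94%
compound 2 `COc1cc(Cl)cc(-c2nn(-c3cccc(NC(=O)Nc4ccc(Cl)c(C(F)(F)F)c4)c3)cc2-c2ccncc2)c1`, 97%

Working notes. In a functional assay on NCI-H226 cells (Homo sapiens) for inhibition, read by sulforhodamine B assay, with a stated time of 48 h, tested at 0.01 uM (a lower number here means a stronger effect, a higher number a weaker effect of the compound at the concentration tested), compound 1 gives 94%. In this assay compound 2 gives 97%, the higher of the two numbers available, with compound 1 the nearest and within the scatter of it, so no order between the two can be read. Both compounds sit near the top of the scale, that is, neither shows much effect at the concentration tested.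

Compound 3 `COc1cc(Cl)cc(-c2nn(-c3cccc(NC(=O)Nc4ccc(Cl)c(Cl)c4)c3)cc2-c2ccncc2)c1` has not been measured. It differs from compound 2 in one place: chloro in place of trifluoromethyl on an aromatic carbon. Within the data shown here, compound 1 already carries the 3,4-dichlorophenyl group on the urea, though it differs from compound 2 elsewhere as well, so no clean step for this change is available. Given that compound 1 and compound 2 lie within the scatter of each other, the expected step of a number 2 percentage points lower from compound 2 to compound 3 (within the scatter) is none beyond the scatter. Compound 3 is therefore estimated at 95%, with a range from 85% to 103%, expected to stay near the weak-effect end like compound 1 and compound 2.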

Compound 3, a percentage reported as activity, at one concentration (the size of the read-out at that concentration, not a potency): 96%
The estimate for compound 3 lay 1 percentage points below the measured number; measured number inside the range.
By their numbers in this assay, from the lowest: compounds 1, 3 and 2 (each within the scatter of the next).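

In this assay, among these compounds, putting chloro in place of trifluoromethyl on the aromatic carbon of the urea aryl ring gives a number 1 percentage points lower from compound 2 to compound 3 (within the scatter) and provides the first clean reading of this change, which does not separate the two groups at the concentration tested. The second one-place pair concerns a different site, the oxygen on the other aromatic ring, where methyl in place of hydrogen gives a number 2 percentage points higher from compound 1 to compound 3 (within the scatter) and again does not separate the two compounds. No measured information is available that could account for these read-outs.

From the compounds shown here alone, all three compounds sit near the weak-effect end of the scale at this single concentration, so it remains open whether either change would matter where the effect is larger. Going by these compounds, it is also open whether an amine or a carboxylic acid at this position, in place of chloro or trifluoromethyl, would move the read-out away from that end of the scale.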